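The compounds below may be only part of what the source reports. "The series", "measured", "known", "first", "only" and "open" are said of these compounds alone.

Measured compounds:
compound 1 `C[C@@H](NC(=O)Nc1ccccc1F)c1ccccc1` — 97%
compound 2 `C[C@@H](NC(=O)Nc1cccc(F)c1)c1ccccc1` — 99%

In an ADME assay on the whole organism with Oryza sativa as the target, tested at 0.1 uM (on this read-out lower numbers stand for a stronger effect and higher numbers for a weaker effect at the one concentration tested), compound 2 gives 99% and so stands at the top of the two numbers, yet compound 1 with 97% lies within the scatter of it, so the two read alike. Compound 3 `C[C@@H](NC(=O)Nc1cc(F)ccc1F)c1ccccc1` is not yet measured. It differs from compound 2 in one place: fluoro in place of hydrogen on an aromatic carbon. For the measured compounds named here, no step between measured compounds is available to judge this change, so in this assay no step beyond the scatter is expected; the expected step is a number 3 percentage points lower from compound 2 to compound 3 (within the scatter). Compound 3 is expected to give 96%, between 85% and 100%.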

Compound 3, a percentage reported as activity, at one concentration (the size of the read-out at that concentration, not a potency): 100%
Beside the measured number, compound 3's estimate is 4 percentage points below it, and the stated range covers the measured number.
By their numbers in this assay, from the lowest: compounds 1, 2 and 3 (each within the scatter of the next).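

In this assay, fluoro in place of hydrogen on an aromatic carbon, ortho to a large group and para to a fluoro group, gives no readable difference: the step is a number 1 percentage points higher from compound 2 to compound 3 (within the scatter) and, from the other single-fluoro compound, a number 3 percentage points higher from compound 1 to compound 3 (within the scatter). A ring with two fluoro groups therefore reads alike with either ring carrying one. Nothing measured here offers an explanation for this result.

Going by these compounds, whether an amine or a carboxylic acid at this place would give a step beyond the scatter stays open. So does whether any change on this ring can do so, since all three compounds read alike.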